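The source may hold more compounds than are shown below. What is called first, only, known or untested is meant among the compounds shown, and "the series" means these compounds.

Among the measured compounds shown here, compound 3 `Nc1ncnc2c1nc(Br)n2CCCO` is the one member of this small set that returns a number in a functional assay on CHO cells for antagonist activity at adenosine receptor A2b (Homo sapiens) (on this read-out lower numbers stand for stronger inhibition and higher numbers for weaker inhibition), where compound 3 gives 5100 nM. Compound 1 `CCCn1cnc2ncnc(N)c21` reaches only a limit of the assay in this assay, namely > 30000 nM. Compound 2 `CC(C)Cn1cnc2c(N)ncnc21` likewise stops at a limit in this assay, reported as > 30000 nM. Two of the three readings therefore share (the limit of > 30000 nM in this assay, at which 2 of the 3 values shown sit), and compound 3 stands apart from them with a measured value.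

Compound 4 `C=CCCn1c(Br)nc2c(N)ncnc21` has not yet been tested. It differs from compound 3 by vinyl in place of hydroxymethyl on a saturated chain carbon, two bonds along the chain from an aromatic nitrogen, so that the 3-hydroxypropyl chain of compound 3 becomes a but-3-en-1-yl chain in compound 4. For the measured compounds named here, no step between measured compounds is available to calibrate such a change in this assay, so its size is uncertain. The expected step is a 1.2-fold higher number from compound 3 to compound 4 (0.07 log units; within the scatter), which is not anticipated to exceed the usual scatter in either direction. Compound 4 is accordingly estimated at 6000 nM, with a range from 1500 nM to 25000 nM.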

Compound 4, inhibition constant: > 30000 nM
Compound 4: only a limit was reported; the forecaster's own chance of this, stated with the estimate: 20%; at least 5.0-fold (0.69 log units) between middle value and limit.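

Replacing hydroxymethyl with vinyl on a saturated chain carbon, two bonds along the chain from an aromatic nitrogen, gives in this assay an at least 5.8-fold higher number from compound 3 to compound 4 (0.76 log units; beyond the scatter). Among the compounds shown here, this is the first step that can be read in the set, and it shows that this position is not indifferent to the change, which swaps a group with one hydrogen-bond donor and one acceptor for a group with neither. Compound 4 gives only a limit of the assay, which places it with compound 1 and compound 2: the limit of > 30000 nM in this assay, at which 3 of the 4 values shown sit.

The compounds shown leave open whether another chain end, such as an amine, a methoxy group or a carboxylic acid, would return a measured value in this assay. On these data alone, with only a limit for compound 4, the true size of the step also remains unknown.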